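This account rests on a few compounds, and the source may have more. Where it says the series, first, only, none or still open, it means among the compounds named here.

The measured compounds:

Compound 1, `CCc1ccccc1-c1nc(N)nc(N)n1`, gives 20% in a functional assay on the whole organism with Rattus norvegicus as the target, at a dose of 20 mg/kg by the intraperitoneal route; on this read-out lower numbers stand for less inhibition and higher numbers for more inhibition at the one dose given (going by the name of the read-out).
Compound 2, `CS(=O)(=O)c1cccc(-c2nc(N)nc(N)n2)c1`, gives -6% in this assay.

Compound 2 stands lowest of the two numbers shown; the gap up to compound 1 lies beyond the usual scatter of repeated measurements, so the two do differ. Compound 3, `CSc1cccc(-c2nc(N)nc(N)n2)c1`, has not yet been measured. It differs from compound 2 in one place: methylsulfanyl in place of methylsulfonyl on an aromatic carbon.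

Within the data shown here, no measured pair here differs in one place, so no step of this kind has been seen, and the expectation rests on the two values alone. Compound 1 carries a two-carbon chain on the same ring and reaches 20%, and methylsulfanyl is nearer to that chain in size than methylsulfonyl is. A modest rise is therefore expected, with the step from compound 2 to compound 3 estimated at a number 16 percentage points higher from compound 2 to compound 3 (beyond the scatter), roughly at the edge of the scatter. Compound 3 is expected to give about 10% in this assay, within a range from -10% to 30%.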

Compound 3, a percentage reported as inhibition, in the whole organism at one dose (the size of the read-out at that dose, not a potency): 49%
Beside the measured number, compound 3's estimate is 39 percentage points below it, outside the stated range (above it).
By their numbers in this assay, from the lowest: compound 2; then compound 1; then compound 3.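

Among these compounds, compound 2 and compound 3 are the first pair here that differ in only one place, so the change in this assay can be tied to a single swap on this aromatic carbon. Putting methylsulfanyl in place of methylsulfonyl gives a number 55 percentage points higher from compound 2 to compound 3 (beyond the scatter) as a large step, which shows that the result at this position depends strongly on the group it carries, even though the swap only removes the two oxygen atoms and keeps the sulfur and the carbon. Nothing measured here explains why this swap has so large an effect.

From the compounds shown here alone, it remains open whether the sulfur matters, which methoxy at this position could test, and whether a longer chain such as ethylsulfanyl would go further. Also open, going by these compounds, is whether methylsulfanyl would give a similar step on another carbon of the ring.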